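A few compounds are considered here, and "the series" means these few. Any claim that something is new, unique, unknown or untested is made for them only; others in the source may bear on it.

Measured so far in an ADME assay on HUVEC cells (Homo sapiens) for inhibition, read by MTT assay, with a stated time of 48 h; on this read-out higher numbers stand for weaker inhibition and lower numbers for stronger inhibition:
compound 1 `COc1cc(/C=N/Nc2nc(-c3ccc(Br)cc3)cs2)cc(Br)c1OC`: > 100000 nM
compound 2 `COc1cc(/C=N/Nc2nc(-c3cccc(Br)c3)cs2)c(Br)c(Br)c1OC`: > 100000 nM

Compound 1 `COc1cc(/C=N/Nc2nc(-c3ccc(Br)cc3)cs2)cc(Br)c1OC` gives in this assay only a limit, > 100000 nM. Compound 2 `COc1cc(/C=N/Nc2nc(-c3cccc(Br)c3)cs2)c(Br)c(Br)c1OC` likewise gives in this assay only a limit, > 100000 nM. Within the data shown here, both values shown thus sit at the same limit (the limit of > 100000 nM in this assay, at which 2 of the 2 values shown sit), so no number separates the two compounds and no step between measured compounds can be counted.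

Compound 3 `COc1cc(/C=N/Nc2nc(-c3ccc(Br)cc3)cs2)c(Br)c(Br)c1OC` has not yet been measured in this assay. It differs from compound 2 by 4-bromophenyl in place of 3-bromophenyl on an aromatic carbon, the place being next to the ring nitrogen and two ring bonds from the ring sulfur. Among the measured compounds shown here, the 4-bromophenyl group is the one carried by compound 1, which also sits at the limit.

With both measured compounds at the limit, the step from compound 2 to compound 3 is expected to be none beyond the scatter, most likely ending at the same limit, as a number no higher from compound 2 to compound 3 (the limit leaves the size open). Compound 3 is therefore estimated at 100000 nM, within 50000 nM to 200000 nM.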

Compound 3, half-maximal inhibitory concentration: > 100000 nM
Compound 3: no number, only a limit; the forecaster's own chance of this, stated with the estimate: 85%; the middle value lies on the limit itself.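

In this assay compound 3 gives > 100000 nM, a limit and not a number. Among these compounds, no step from compound 1 or compound 2 to compound 3 can be read: the limit of > 100000 nM in this assay, at which 3 of the 3 values shown sit. The compounds shown leave open whether 4-bromophenyl and 3-bromophenyl differ at all in this assay, and whether any compound of the series gives a readable number there.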